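A methoxy-bearing ring in place of a methyl-bearing one

The source may hold more compounds than are shown below. What is called first, only, known or untested is meant among the compounds shown, and "the series" means these compounds.

Within the data shown here, compound 2 `Cc1cccc(S(=O)(=O)Nc2ccc3oc(-c4ccccc4)nc3c2)c1` is the only compound with a plain number here: in an ADME assay on HEK293 cells (Homo sapiens) for cytotoxicity, read by resazurin assay, with a stated time of 48 h (on this read-out lower numbers stand for higher toxicity in this test and higher numbers for lower toxicity in this test), compound 2 gives 69000 nM. Compound 1 `O=S(=O)(Nc1ccc2oc(-c3ccccc3)nc2c1)c1cccc(C(F)(F)F)c1` gives > 100000 nM in this assay, which is a limit (the limit of > 100000 nM in this assay, at which 1 of the 2 values shown sits). Among the measured compounds shown here, the step of an at least 1.4-fold lower number from compound 1 to compound 2 (0.16 log units; that floor lies within the scatter) is the sole measured step, and it concerns a different group on the shared core. Compound 3 `COc1ccccc1S(=O)(=O)Nc1ccc2oc(-c3ccccc3)nc2c1` carries 2-methoxyphenyl in place of 3-methylphenyl on a sulfonyl sulfur. For the measured compounds named here, no measured step touches that change, so he expects a step no larger than the scatter, in no set direction. He estimates compound 3 at 80000 nM, between 35000 nM and 170000 nM. The step of a 1.2-fold higher number from compound 2 to compound 3 (0.06 log units; within the scatter) is thus what he expects.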

Compound 3, half-maximal cytotoxic concentration: 41000 nM
Beside the measured number, compound 3's estimate is 2.0-fold (0.29 log units) above it; the range from low to high includes it.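

Among these compounds, the change to 2-methoxyphenyl on a sulfonyl sulfur gives the first step in this assay with a plain number at both ends: a 1.7-fold lower number from compound 2 to compound 3 (0.23 log units; within the scatter). This exchange of one ring for another, which brings in a hydrogen-bond acceptor, leaves compound 2 and compound 3 within the scatter of each other. Compound 1 still stands only as a limit: the limit of > 100000 nM in this assay, at which 1 of the 3 values shown sits.

The compounds shown leave open whether an amine or a carboxylic acid on this ring would give a step beyond the scatter. They also leave open what a longer chain in place of the ring on the sulfonyl sulfur would give.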